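Swapping the Benzyl Substituent in a Sulfonamide Series

The compounds below may be only part of what the source reports. "The series", "measured", "known", "first", "only" and "open" are said of these compounds alone.

Measured in a functional assay on MCF7 cells (Homo sapiens) for inhibition, read by MTT assay, with a stated time of 72 h; a lower number here means a stronger inhibitor of growth, a higher number a weaker inhibitor of growth:
Compound 1, `O=S(=O)(NCCCNCc1ccc(C(F)(F)F)cc1)c1cc(C(F)(F)F)cc(C(F)(F)F)c1`: 1400 nM
Compound 2, `O=S(=O)(NCCCNCc1ccc(-c2ccccc2)cc1)c1cc(C(F)(F)F)cc(C(F)(F)F)c1`: 1700 nM

Compound 1 gives the lowest of these two numbers, but compound 2 sits within the scatter of it, so neither can be called the stronger inhibitor. Compound 3, `COc1ccccc1CNCCCNS(=O)(=O)c1cc(C(F)(F)F)cc(C(F)(F)F)c1`, is not yet measured. It differs from compound 1 by 2-methoxyphenyl in place of 4-(trifluoromethyl)phenyl on a saturated chain carbon bound to an amine nitrogen. Going by the values given here, the only measured step, a 1.2-fold higher number from compound 1 to compound 2 (0.08 log units; within the scatter), also alters this group and stays within the scatter, so no step beyond the scatter in this assay is expected for compound 3, in either direction. Compound 3 is therefore estimated at 1600 nM, between 700 nM and 3500 nM. For compound 3 this means an expected 1.1-fold higher number from compound 1 to compound 3 (0.06 log units; within the scatter).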

Compound 3, concentration for 50% growth inhibition: 2600 nM
Beside the measured number, compound 3's estimate is 1.6-fold (0.21 log units) below it, and the stated range covers the measured number.
By their numbers in this assay, from the lowest: compounds 1, 2 and 3 (each within the scatter of the next).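

Replacing 4-(trifluoromethyl)benzyl with 2-methoxybenzyl gives a 1.9-fold higher number from compound 1 to compound 3 (0.27 log units; within the scatter) in this assay. The earlier step changed only a group on the benzyl ring, whereas this one removes the trifluoromethyl group, moves to a 2-methoxy pattern and adds a hydrogen-bond acceptor, yet the number still stays within the scatter. No supporting measurement is available to explain this result. On these data alone, whether an amine or a carboxylic acid on the benzyl group would give a step beyond the scatter remains open. So does the effect of a longer chain in place of the benzyl group.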